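The source may report more compounds than this note shows. Statements on the series, on what has been measured and on what is new or still open speak of the compounds shown alone.

Compound 2 `Nc1ccccc1NC(=O)c1ccc(COc2ccc3ncnc(Nc4cccc(Br)c4)c3c2)cc1` gives 1300 nM in a functional assay on A549 cells (Homo sapiens) for cytotoxicity, read by resazurin assay (on this read-out lower numbers stand for stronger inhibition and higher numbers for weaker inhibition), the highest of the three numbers in hand. Compound 3 `C#Cc1cccc(Nc2ncnc3cc(NC(=O)c4ccc(C(=O)Nc5ccccc5N)s4)ccc23)c1` gives 820 nM, a gap within the scatter, and compound 1 `C#Cc1cccc(Nc2ncnc3ccc(S(=O)(=O)n4ccc(/C=C/C(=O)NO)c4)cc23)c1` gives 240 nM, a gap beyond it. Compound 4 `C#Cc1cccc(Nc2ncnc3ccc(OCc4ccc(C(=O)Nc5ccccc5N)cc4)cc23)c1` differs from compound 2 by ethynyl in place of bromo on an aromatic carbon. Going by the values given here, no measured pair isolates this change; compounds 1 and 3 carry the (3-ethynylphenyl)amino group but differ from compound 2 in other parts too, so their lower numbers are only weak support. The step expected is a 1.3-fold lower number from compound 2 to compound 4 (0.11 log units; within the scatter), toward a somewhat lower number but not clearly beyond the scatter. Compound 4 is therefore estimated at 1000 nM, with a range of 400 nM to 2500 nM.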

Compound 4, half-maximal inhibitory concentration: 900 nM
For compound 4 the middle estimate is 1.1-fold (0.05 log units) above the measured one; measured number inside the range.
By their numbers in this assay, from the lowest: compound 1; then compounds 3, 4 and 2 (each within the scatter of the next).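

In this assay, going by these compounds alone, this is the only pair that isolates the change: a 1.4-fold lower number from compound 2 to compound 4 (0.16 log units; within the scatter). On this read-out, ethynyl and bromo on this aromatic carbon therefore cannot be told apart, and the weak support from compounds 1 and 3 gains nothing from this pair. No supporting measurement bears on why the two groups read alike.

From the compounds shown here alone, whether an amine or a carboxylic acid on this aromatic carbon would give a step beyond the scatter remains open. Also open, going by these compounds, is whether ethynyl and bromo would read alike on the cores of compounds 1 and 3.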